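Triazole N-aryl variation on a triterpenoid farnesyl ester series

A few compounds are considered here, and "the series" means these few. Any claim that something is new, unique, unknown or untested is made for them only; others in the source may bear on it.

Measured so far in a functional assay on DU-145 cells (Homo sapiens) for antiproliferative activity, read by MTT assay, with a stated time of 48 h; a lower number here means a stronger inhibitor, a higher number a weaker inhibitor:
compound 1 `C/C(=C\CC/C(C)=C/CC[C@@H]1[C@@]2(C)CCC(=O)C(C)(C)[C@H]2CC[C@@]1(C)O)CC/C=C(\C)C(=O)OCc1cn(-c2ccccc2Br)nn1` — > 150000 nM, a limit of the assay
compound 2 `C#CCOC(=O)/C(C)=C/CC/C(C)=C/CC/C(C)=C/CC[C@@H]1[C@@]2(C)CCC(=O)C(C)(C)[C@H]2CC[C@@]1(C)O` — 46100 nM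
compound 3 `COc1ccc(-n2cc(COC(=O)/C(C)=C/CC/C(C)=C/CC/C(C)=C/CC[C@@H]3[C@@]4(C)CCC(=O)C(C)(C)[C@H]4CC[C@@]3(C)O)nn2)cc1` — 135000 nM

Compound 1 reaches only the limit of > 150000 nM in this assay, at which 1 of the 3 values shown sits, and gives no number. Of the two numbers, compound 3 stands highest; its nearest neighbour is compound 2, and the step from compound 3 to compound 2 is beyond the scatter. Among the compounds with values here, replacing the triazole-bearing ester by the propargyl ester is the one step that moves this assay: an at least 3.2-fold lower number from compound 1 to compound 2 (0.51 log units; beyond the scatter). Changing the aryl group on the triazole nitrogen does not: an at least 1.1-fold lower number from compound 1 to compound 3 (0.04 log units; that floor lies within the scatter).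

Compound 4 `C/C(=C\CC/C(C)=C/CC[C@@H]1[C@@]2(C)CCC(=O)C(C)(C)[C@H]2CC[C@@]1(C)O)CC/C=C(\C)C(=O)OCc1cn(-c2ccccc2F)nn1` is not yet measured. It differs from compound 3 as follows: 2-fluorophenyl in place of 4-methoxyphenyl on an aromatic nitrogen. This is again an exchange of the aryl group on the aromatic nitrogen, so the step from compound 1 to compound 3 is the one that bears on it, and that step lay within the scatter. Compound 4 is therefore expected to sit close to compound 3, with no step beyond the scatter, a 1.1-fold higher number from compound 3 to compound 4 (0.05 log units; within the scatter). The estimate for compound 4 in this assay is 150000 nM, within a range from 60000 nM to 400000 nM, with a real chance that only the limit is reported.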

Compound 4, half-maximal inhibitory concentration: > 150000 nM
Compound 4: only a limit was reported; the forecaster's own chance of this, stated with the estimate: 45%; the middle value sits exactly at the limit.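

With the 2-fluorophenyl group on the aromatic nitrogen of the triazole, compound 4 gives only a limit of the assay, not a number, in this assay: the limit of > 150000 nM in this assay, at which 2 of the 4 values shown sit.

A third aryl group now shows the same picture, since exchanging 4-methoxyphenyl for 2-fluorophenyl gives an at least 1.1-fold higher number from compound 3 to compound 4 (0.04 log units; that floor lies within the scatter), and the aryl exchange has still produced no step beyond the scatter. The separation from the propargyl ester also holds for a second halogen-bearing aryl triazole, with an at least 3.2-fold higher number from compound 2 to compound 4 (0.51 log units; beyond the scatter), so the gap seen with the 2-bromophenyl group is not confined to that one group.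

The fluoro for bromo exchange on the aromatic carbon cannot be read, as both compounds carrying these groups stand at the limit, and any order among the halogen-bearing aryl groups remains hidden. On these data alone, it stays open whether an aryl group carrying an amine or a carboxylic acid, or a longer chain in place of the aryl group on the triazole nitrogen, would bring the triazole esters down to the level of compound 2.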